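The compounds below may be only part of what the source reports. "The series", "measured", "known", "first", "only" and "open" are said of these compounds alone.

In an assay on isolated protein for displacement of a labelled ligand from D(4) dopamine receptor (Homo sapiens) (a lower number here means a stronger inhibitor, a higher number a weaker inhibitor), compound 1 `O=C(NC1CCN(Cc2cccc(C(F)(F)F)c2)CC1)c1cccc2ccccc12` gives 119 nM and compound 2 `O=C(NC1CCN(Cc2cccc(C(F)(F)F)c2)CC1)c1ccc2ccccc2c1` gives 103 nM. Going by the values given here, the only measured step, a 1.2-fold lower number from compound 1 to compound 2 (0.06 log units; within the scatter), concerns the naphthyl group on the carbonyl carbon, so compound 2 stands at the lower of two numbers without being separable from compound 1. Compound 3 `Cc1cccc(CN2CCC(NC(=O)c3ccc4ccccc4c3)CC2)c1` differs from compound 2 at the other end of the shared core: methyl in place of trifluoromethyl on an aromatic carbon. Among the compounds with values here, no measured step touches this aromatic ring, so there is nothing in this assay to set the direction or size of the change, and the step is expected to stay within the range of ordinary scatter rather than to move clearly one way. Compound 3 is therefore expected to give about 150 nM in this assay, between 50 nM and 450 nM, which amounts to a 1.5-fold higher number from compound 2 to compound 3 (0.16 log units; within the scatter).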

Compound 3, inhibition constant: 11 nM
Beside the measured number, compound 3's estimate is 14-fold (1.13 log units) above it, and the stated range ends above it.
By their numbers in this assay, from the lowest: compound 3; then compounds 2 and 1 (each within the scatter of the next).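

In this assay the group on this aromatic ring counts for far more than the naphthyl attachment did: that earlier change gave a 1.2-fold lower number from compound 1 to compound 2 (0.06 log units; within the scatter) while going from 3-(trifluoromethyl)phenyl to 3-methylphenyl gives a 9.4-fold lower number from compound 2 to compound 3 (0.97 log units; beyond the scatter) and so clears the scatter. The position is therefore sensitive to what it carries, and of the two groups seen there, methyl goes with the lower number, although this rests on a single pair of compounds. Nothing measured here explains why this swap has an effect of this size. As far as these compounds go, whether hydrogen, chlorine, methoxy or a longer chain at this place would go lower still or lose the gain remains open. So does whether the same swap would give a step of this size with naphthalen-1-yl on the carbonyl carbon, as in compound 1.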